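This account rests on a few compounds, and the source may have more. Where it says the series, first, only, none or still open, it means among the compounds named here.

Compound 1 `[O-][n+]1nc(NCOCc2ccc(Cl)cc2)[n+]([O-])c2ccccc21`: 810 nM
Compound 2 `[O-][n+]1nc(NCOC2CCCCC2)[n+]([O-])c2ccccc21`: 4170 nM

In a functional assay on SMMC-7721 cells (Homo sapiens) for cytotoxicity, read by MTT assay, with a stated time of 72 h (a higher number here means a weaker inhibitor, a lower number a stronger inhibitor), compound 1 gives 810 nM and compound 2 gives 4170 nM, so compound 1 has the lower of the two numbers and the gap to compound 2 is beyond the usual scatter. Compound 3 `CCOCNc1n[n+]([O-])c2ccccc2[n+]1[O-]` has not yet been measured. Its difference from compound 1 is methyl in place of 4-chlorophenyl on a saturated chain carbon bound to an oxygen on a saturated carbon. Going by the values given here, no measured pair shows this change, so the expectation rests only on compounds 1 and 2; the loss of the ring is expected to weaken inhibition by a moderate step of a 3.7-fold higher number from compound 1 to compound 3 (0.57 log units; beyond the scatter). Compound 3 is estimated at 3000 nM, within 1000 nM to 9000 nM.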

Compound 3, half-maximal inhibitory concentration: 4230 nM
Beside the measured number, compound 3's estimate is 1.4-fold (0.15 log units) below it; the measured number falls inside the stated range.
By their numbers in this assay, from the lowest: compound 1; then compounds 2 and 3 (each within the scatter of the next).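

In this assay, replacing 4-chlorophenyl with methyl gives a 5.2-fold higher number from compound 1 to compound 3 (0.72 log units; beyond the scatter) and so weakens inhibition. Ethyl in place of cyclohexyl gives a 1.0-fold higher number from compound 2 to compound 3 (0.01 log units; within the scatter) and makes no readable difference, so among these compounds, having a ring at this end of the side chain does not by itself give the lower number. Nothing available explains these numbers.

Going by these compounds, whether the advantage of compound 1 comes from its chlorine or from its aromatic ring stays open. Plain phenyl, a longer chain or an amine at this position remain untested here.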